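This account rests on a few compounds, and the source may have more. Where it says the series, first, only, none or still open, it means among the compounds named here.

Working notes on the series, read in a functional assay for inhibition, with Homo sapiens as the target; a lower number here means a stronger inhibitor, a higher number a weaker inhibitor. Compound 1 (`Cc1cc2c(cc1C(=O)N=C(N)N)S(=O)(=O)CC2(C)O`) gives 115 nM, compound 2 (`CCC1CS(=O)(=O)c2cc(C(=O)N=C(N)N)c(C)cc21`) gives 78 nM, and compound 3 (`COC1(C)CS(=O)(=O)c2cc(C(=O)N=C(N)N)c(C)cc21`) gives 321 nM, the highest of the three numbers. Compound 4 (`COC1CS(=O)(=O)c2cc(C(=O)N=C(N)N)c(C)cc21`) is not yet measured. It follows from compound 3 by hydrogen in place of methyl on a saturated ring carbon. Within the data shown here, no measured step makes this same change. The nearest is a 2.8-fold higher number from compound 1 to compound 3 (0.45 log units; beyond the scatter), for methyl in place of hydrogen on an oxygen on a saturated carbon, so it bears only indirectly: there, an added methyl went with a modest rise in the number. Compound 2 also carries a hydrogen on that ring carbon and shows 78 nM, a lower number than that of compound 3, but the two differ in more than this one place. A modest move towards a lower number is therefore expected in this assay, similar in size to the measured step. The estimated step is a 1.8-fold lower number from compound 3 to compound 4 (0.25 log units; within the scatter). The expected value for compound 4 is 180 nM, with an estimated range of 70 nM to 450 nM.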

Compound 4, half-maximal inhibitory concentration: 208 nM
Compound 4: the middle estimate sits 1.2-fold (0.06 log units) below what was measured; measured number inside the range.
By their numbers in this assay, from the lowest: compounds 2, 1, 4 and 3 (each within the scatter of the next, the first and the last beyond it).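

In this assay, taking the methyl off this saturated ring carbon of the methoxy compounds gives a 1.5-fold lower number from compound 3 to compound 4 (0.19 log units; within the scatter), so the methyl carries no readable weight here while the methoxy stays in place. With hydrogen on the same carbon, methoxy in place of ethyl gives a 2.7-fold higher number from compound 2 to compound 4 (0.43 log units; beyond the scatter), a modest step showing that the number responds to the choice of the other group on this carbon more clearly than to the methyl. Nothing on hand gives a reason for either step.

From the compounds shown here alone, whether the methyl stays as silent alongside hydroxyl or ethyl is still open. Also open, going by these compounds, is how an amine, a carboxylic acid or a chain longer than ethyl on this saturated ring carbon would read in this assay, so the tolerance of this position is known only for a few small groups.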